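The compounds below may be only part of what the source reports. "The series", "measured", "known", "first", "only" and "open" are said of these compounds alone.

Measured so far in a functional assay on SMMC-7721 cells (Homo sapiens) for antiproliferative activity, read by MTT assay, with a stated time of 72 h; on this read-out lower numbers stand for stronger inhibition and higher numbers for weaker inhibition: compound 1 `CN(C(=O)c1ccc(F)cc1)c1ccc2[nH]c(-c3n[nH]c4ccccc34)cc2n1` gives 9150 nM; compound 2 `Cc1ccc(S(=O)(=O)N(C)c2ccc3[nH]c(-c4n[nH]c5ccccc45)cc3n2)cc1` gives 16300 nM.

Compound 2 stands highest of the two numbers, its nearest neighbour being compound 1, since a 1.8-fold higher number from compound 1 to compound 2 (0.25 log units; within the scatter) lies within the scatter. Compound 3 `CN(C(=O)Nc1ccccc1)c1ccc2[nH]c(-c3n[nH]c4ccccc34)cc2n1` differs from compound 2 by phenylcarbamoyl in place of (4-methylphenyl)sulfonyl on a nitrogen on an aromatic ring. Within the data shown here, only that one step bears on this change, and it was small; a carbonyl-type group returns in place of the sulfonyl, as in compound 1. Compound 3 is therefore expected to land near compound 1, an estimated 1.6-fold lower number from compound 2 to compound 3 (0.21 log units; within the scatter). The estimate for compound 3 in this assay is 10000 nM, in the range 4000 nM to 25000 nM.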

Compound 3, half-maximal inhibitory concentration: 280 nM
Estimate against measurement, compound 3: 36-fold (1.55 log units) above; the measured number lies below the stated range.
By their numbers in this assay, from the lowest: compound 3; then compounds 1 and 2 (each within the scatter of the next).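

In this assay this nitrogen proves able to shift the number far: phenylcarbamoyl gives a 58-fold lower number from compound 2 to compound 3 (1.77 log units; beyond the scatter), whereas the earlier step stayed within the scatter. Compound 1 also carries a carbonyl here, yet anilino in place of 4-fluorophenyl on that carbonyl carbon still gives a 33-fold lower number from compound 1 to compound 3 (1.51 log units; beyond the scatter), so keeping the carbonyl is not enough to reach this number. No measurement at hand explains the large steps.

Still open, from the compounds shown here alone, is whether a benzylamino or methylamino group on that carbonyl carbon would keep the low number. The same holds for a 4-fluoroanilino group, or for hydrogen in place of the methyl on the nitrogen.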